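From Ethyl to 3-Ethynylphenyl on the Shared Core

This account rests on a few compounds, and the source may have more. Where it says the series, first, only, none or still open, it means among the compounds named here.

In a functional assay on HOS-TE85 cells (Homo sapiens) for inhibition, read by CCK-8 assay, with a stated time of 72 h (on this read-out higher numbers stand for weaker inhibition and lower numbers for stronger inhibition), compound 1 (`CCN(CC)c1ccc(N2C(=O)CSC2c2cccc(C(=O)NCCCCc3ccccc3)c2)cc1`) gives > 1000 nM, which is a limit and not a number. Compound 2 (`CCN1C(=O)CSC1c1cccc(C(=O)NCCCCc2ccccc2)c1`) gives > 1000 nM, also a limit. Compound 3 (`C#Cc1cccc(N2C(=O)CSC2c2cccc(C(=O)NCCCCc3ccccc3)c2)c1`) carries 3-ethynylphenyl in place of ethyl on an amide-type nitrogen in a ring. For the measured compounds named here, the only measured change at this nitrogen is a step that the two limits leave unreadable from compound 1 to compound 2, so it offers no size to carry over, and both compounds sit at the limit of > 1000 nM in this assay, at which 2 of the 2 values shown sit. Only a small change of uncertain direction is expected, the estimated step being a step that the limit leaves unreadable from compound 2 to compound 3. For compound 3 the expected value is 2000 nM, estimated to lie between 300 nM and 10000 nM.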

Compound 3, half-maximal inhibitory concentration: 149 nM
Compound 3: middle estimate off by 13-fold (1.13 log units), on the high side; measured number outside the range, below it.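

For the compounds shown here, on the amide-type nitrogen in a ring, 3-ethynylphenyl in place of ethyl brings an at least 6.7-fold lower number from compound 2 to compound 3 (0.82 log units; beyond the scatter) in this assay, the first readable number for the shared core. An aromatic ring on this nitrogen does not by itself account for this, since 3-ethynylphenyl in place of 4-(diethylamino)phenyl brings an at least 6.7-fold lower number from compound 1 to compound 3 (0.82 log units; beyond the scatter) on the same core. Both steps are minimum sizes, as compounds 1 and 2 each stand at a limit: the limit of > 1000 nM in this assay, at which 2 of the 3 values shown sit.

The ring and the triple bond entered together, so their shares in the step remain unseparated. On these data alone, whether plain phenyl or 3-cyanophenyl on this nitrogen would match compound 3 remains open.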